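The compounds below may be only part of what the source reports. "The series", "measured", "known", "first", "only" and "open" are said of these compounds alone.

In a functional assay on A-431 cells (Homo sapiens) for inhibition, read by MTT assay, with a stated time of 72 h (on this read-out higher numbers stand for weaker inhibition and lower numbers for stronger inhibition), three compounds with the shared core have been measured so far, and they differ only in one group on an aromatic carbon. Compound 1 `COc1ccc(-c2nnc(SCCCN3CCN(c4nc5ccccc5o4)CC3)o2)cc1` gives 52700 nM in this test, compound 2 `O=[N+]([O-])c1ccc(-c2nnc(SCCCN3CCN(c4nc5ccccc5o4)CC3)o2)cc1` gives 46900 nM and compound 3 `Cc1ccc(-c2nnc(SCCCN3CCN(c4nc5ccccc5o4)CC3)o2)cc1` gives 100000 nM there. Compound 2 cannot be told apart from compound 1: the data show a 1.1-fold lower number from compound 1 to compound 2 (0.05 log units; within the scatter) in that comparison. Against compound 3 it stands apart only modestly, with a 2.1-fold higher number from compound 2 to compound 3 (0.33 log units; beyond the scatter) on record, while the remaining comparison gives a 1.9-fold higher number from compound 1 to compound 3 (0.28 log units; within the scatter) for that pair.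

The next compound, compound 4 `Brc1ccc(-c2nnc(SCCCN3CCN(c4nc5ccccc5o4)CC3)o2)cc1`, puts bromo in place of nitro on an aromatic carbon, para to a large group, so that 4-nitrophenyl becomes 4-bromophenyl: bromo in place of nitro on an aromatic carbon. Within the data shown here, no bromo compound has been measured yet, so the only guide is the three exchanges at this same place. All of them were small, and the largest only just cleared the scatter. A step of similar small size is therefore expected, leaning slightly towards a higher number and probably staying within the scatter. The estimated move is a 1.3-fold higher number from compound 2 to compound 4 (0.12 log units; within the scatter) and nothing larger is expected. For compound 4 the estimated value is 62000 nM (range 33000 nM to 115000 nM).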

Compound 4, half-maximal inhibitory concentration: 57800 nM
For compound 4 the middle estimate is 1.1-fold (0.03 log units) above the measured one; the measured number falls inside the stated range.
By their numbers in this assay, from the lowest: compounds 2, 1, 4 and 3 (each within the scatter of the next, the first and the last beyond it).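

In this assay, bromo on this aromatic carbon, para to a large group, cannot be told apart from nitro (a 1.2-fold higher number from compound 2 to compound 4 (0.09 log units; within the scatter)) or from methoxy (a 1.1-fold higher number from compound 1 to compound 4 (0.04 log units; within the scatter)), although the single heavy atom of bromo replaces the three heavy atoms and two hydrogen-bond acceptors of nitro. The exchange with methyl also stays inside the usual scatter (a 1.7-fold lower number from compound 3 to compound 4 (0.24 log units; within the scatter)), so compound 4 cannot be separated from any of the other three compounds, and the one printed separation beyond the scatter, between compound 2 and compound 3, remains a modest one. Nothing on record accounts for how little these exchanges change the number.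

What the four compounds leave open is whether an amine, a carboxylic acid or a hydroxyl on this carbon would move the number clearly beyond the scatter, since only four groups have been compared here and all of them stand at this one place. Going by these compounds, it also remains open whether bromo or any of the other groups would behave the same way on a different carbon of the ring, or together with a longer chain in the shared core.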